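The source may report more compounds than this note shows. Statements on the series, on what has been measured and on what is new or still open speak of the compounds shown alone.

Of the compounds shown here, two of this set have been measured in an assay on isolated protein for inhibition of Dihydrofolate reductase (Mus musculus); on this read-out higher numbers stand for higher potency (the scale is a negative logarithm) and lower numbers for lower potency. Compound 1, with the structure `CC1(C)N=C(N)N=C(N)N1c1cccc(CCCCc2ccc(Cl)c(S(=O)(=O)F)c2)c1`, gives 8.37 in this assay, the higher of the two values recorded. Compound 2, with the structure `CC1(C)N=C(N)N=C(N)N1c1ccc(OCc2cccc(S(=O)(=O)F)c2)c(Cl)c1`, gives 7.72 in this assay, a lower figure than that of compound 1, and the gap between the two lies beyond the usual scatter of repeated measurements. Within the data shown here, no pair of measured compounds differs in a single place, so no measured single step is available to guide expectations.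

Compound 3, with the structure `CC1(C)N=C(N)N=C(N)N1c1cccc(CCCCc2cccc(S(=O)(=O)F)c2)c1`, has not yet been measured. It differs from compound 1 in one place: hydrogen in place of chloro on an aromatic carbon. The shared core is untouched, and the chain of four carbons that links the two aromatic rings remains as in compound 1.

Among the measured compounds shown here, with no measured step of this kind at hand, the expectation for compound 3 rests on compound 1 alone. A modest decrease is expected, from compound 1 to compound 3 of a number 0.37 log units lower from compound 1 to compound 3 (beyond the scatter), a step that may well fall within the scatter. Compound 3 is therefore estimated at 8 in this assay, with a range from 7.4 to 8.6.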

Compound 3, logarithm of the reciprocal of the active concentration, log(1/C): 8.1
For compound 3 the middle estimate is 0.10 log units below the measured one; the measured number falls inside the stated range.
By their numbers in this assay, from the lowest: compound 2; then compounds 3 and 1 (each within the scatter of the next).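

In this assay, among these compounds, the exchange of chloro for hydrogen, on an aromatic carbon ortho to a fluorosulfonyl group and para to a large group, gives the first single-place step in this set: a number 0.27 log units lower from compound 1 to compound 3 (within the scatter). With the shared core and the linking chain unchanged, the chloro group at this place is thus not required for a value within the scatter of that of compound 1, something compound 2, which differs from compound 1 in more than one place, could not show. No measurement at hand bears on the reason for this result.

The compounds shown leave open whether another group at this same place, such as a fluoro, a methyl, a methoxy or an amine, would also stay within the scatter, since hydrogen and chloro are the only two seen here. They also leave open whether the exchange of chloro for hydrogen would give a similar step on a shorter or longer chain, or with a carboxylic acid in place of the fluorosulfonyl group.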